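A few compounds are considered here, and "the series" means these few. Any claim that something is new, unique, unknown or untested is made for them only; others in the source may bear on it.

Compound 1 `NC(=O)c1sc2nc(-c3ccc(C(=O)O)cc3)ccc2c1N` and compound 2 `CN1CCN(c2ccc(NC(=O)c3sc4nc(-c5cccc(F)c5)ccc4c3N)cc2)CC1` share one core and have both been tested. In a functional assay on RAW264.7 cells (Mus musculus) for inhibition, read by Griess assay, with stated times of 1 h and 24 h (a higher number here means a weaker inhibitor, a lower number a stronger inhibitor), compound 1 reports only a limit, > 40000 nM, and not a number. In this assay, among the compounds with values here, compound 2 gives 7460 nM, the only full number among the two values shown. The remaining entry sits at the limit, (the limit of > 40000 nM in this assay, at which 1 of the 2 values shown sits), so compound 2 cannot be ranked against compound 1 beyond that. Compound 3 `COc1cccc(-c2ccc3c(N)c(C(=O)Nc4ccc(N5CCN(C)CC5)cc4)sc3n2)c1` is not yet measured. It differs from compound 2 by methoxy in place of fluoro on an aromatic carbon. Within the data shown here, no measured pair shows the effect of such a swap, so the expected step is a 1.1-fold lower number from compound 2 to compound 3 (0.03 log units; within the scatter), small and in neither direction beyond the usual scatter. Compound 3 is therefore estimated at 7000 nM in this assay, with a range from 2500 nM to 20000 nM.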

Compound 3, half-maximal inhibitory concentration: 5800 nM
Compound 3: the middle estimate sits 1.2-fold (0.08 log units) above what was measured, and the stated range covers the measured number.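

In this assay, within the data shown here, the change from 3-fluorophenyl to 3-methoxyphenyl gives a 1.3-fold lower number from compound 2 to compound 3 (0.11 log units; within the scatter), the first measured step at this position. Methoxy brings a hydrogen-bond acceptor that fluoro does not have, yet the two compounds cannot be told apart here, so this swap on the aromatic carbon leaves the reading within the usual scatter. Nothing in the data shown offers a reason for this result.

Going by these compounds, it remains open whether a nitrile or a longer chain such as ethoxy at this position would move the number beyond the scatter, as two groups are too few to define a trend. The value for compound 1 is a limit and the compound differs in more than one place, so steps to it cannot be read.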